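The compounds below may be only part of what the source reports. "The series", "measured", "known", "first", "only" and "open" are said of these compounds alone.

Three hydroxamic acids sharing one core have been measured in a functional assay on MDA-MB-231 cells (Homo sapiens) for antiproliferative activity; on this read-out lower numbers stand for stronger inhibition of growth and higher numbers for weaker inhibition of growth. Compound 1 `O=C(CCC1=CCN(Cc2ccc(C(F)(F)F)cc2)C1=O)NO` gives 3070 nM in this assay. Compound 2 `COc1cccc(CN2CC=C(CCC(=O)NO)C2=O)c1` gives 1770 nM in this assay, and compound 3 `COc1ccccc1CN1CC=C(CCC(=O)NO)C1=O` gives 6030 nM in this assay. On these three numbers compound 1 sits between the other two, but its gap to compound 2, the nearest, and its gap to compound 3, the furthest, both lie within the usual scatter of repeated measurements, so the three compounds cannot be told apart on this read-out.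

Compound 4 `COc1ccc(CN2CC=C(CCC(=O)NO)C2=O)cc1` has not yet been measured. It differs from compound 1 by a single change: methoxy in place of trifluoromethyl on an aromatic carbon. Among the compounds with values here, no measured pair in this set differs in exactly this way, so the size of the step rests on the spread of the three numbers seen so far. Since compound 2 already carries a methoxy on the same ring and gives 1770 nM in this assay, and compound 3 likewise carries one and gives 6030 nM in this assay, the expectation is that the step from compound 1 to compound 4 is a 1.1-fold lower number from compound 1 to compound 4 (0.04 log units; within the scatter), which is no step beyond the scatter. Compound 4 is therefore estimated at 2800 nM in this assay, with a range from 1000 nM to 7500 nM.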

Compound 4, concentration for 50% growth inhibition: 1630 nM
Estimate against measurement, compound 4: 1.7-fold (0.23 log units) above; the range from low to high includes it.
By their numbers in this assay, from the lowest: compounds 4, 2, 1 and 3 (each within the scatter of the next, the first and the last beyond it).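

Within the data shown here, the change from trifluoromethyl to methoxy, on an aromatic carbon para to a large group, is the first single change in this set that can be read in this assay, and it gives a 1.9-fold lower number from compound 1 to compound 4 (0.27 log units; within the scatter) as its step. At this position, then, the two groups cannot be told apart on this read-out, although trifluoromethyl counts 4 heavy atoms and no hydrogen-bond acceptor, while methoxy counts 2 heavy atoms and 1 hydrogen-bond acceptor. No measurement at hand bears on this result or offers an explanation for it.

As far as these compounds go, it remains open whether any group at this position can move the number beyond the scatter, as an amine, a carboxylic acid or a bare hydrogen in place of methoxy would show. All four compounds also share the hydroxamic acid and its chain, so the compounds shown say nothing about how a carboxylic acid in place of the hydroxamic acid, or a longer chain leading to it, would read in this assay.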